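A Hydroxy Analogue at the Cytotoxicity Ceiling

The source may report more compounds than this note shows. Statements on the series, on what has been measured and on what is new or still open speak of the compounds shown alone.

Three nitrobenzamides were tested in an ADME assay on BJ cells (Homo sapiens) for cytotoxicity, with a stated time of 72 h; a lower number here means that less compound is needed, a higher number that more compound is needed for the effect. Compound 1 `O=C(Nc1cc(-c2nc3ccccc3s2)ccc1Cl)c1cc([N+](=O)[O-])ccc1Cl` gave only a limit, > 25000 nM. Compound 2 `Cc1ccc(-c2nc3ccccc3o2)cc1NC(=O)c1cc([N+](=O)[O-])ccc1Cl` likewise reached only a limit, > 14000 nM. Compound 3 `COc1cc(Cl)c(C(=O)Nc2cccc(-c3nc4ccccc4s3)c2)cc1[N+](=O)[O-]` stands at a limit as well, > 25000 nM, so no number places it against the others. Among the measured compounds shown here, all three sit at the limit of > 14000 nM in this assay, at which 1 of the 3 values shown sits, or (the limit of > 25000 nM in this assay, at which 2 of the 3 values shown sit), and no measured step between them exists. Compound 4 `O=C(Nc1cccc(-c2nc3ccccc3s2)c1)c1cc([N+](=O)[O-])c(O)cc1Cl` is not yet measured; it differs from compound 3 by hydrogen in place of methyl on an oxygen on an aromatic ring. With nothing measured to draw on, the change is expected to shift this assay by no more than the usual scatter, an estimated step of a number no higher from compound 3 to compound 4 (the limit leaves the size open). Compound 4 is accordingly expected near 25000 nM, between 8000 nM and 80000 nM, most probably again as a limit only.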

Compound 4, half-maximal effective concentration: > 25000 nM
Compound 4 ended at the assay's limit; the forecaster's own chance of this, stated with the estimate: 75%; the middle value lies on the limit itself.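

Compound 3 and compound 4 both ended as limits in this assay, so no step can be read between them for methoxy to hydroxy. The compounds shown leave open what concentration of any of them gives the effect.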